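Pentylsulfanyl in Place of Pentyloxy: One Step, One Expectation

The compounds below may be only part of what the source reports. "The series", "measured", "known", "first", "only" and "open" are said of these compounds alone.

Compound 1 `CCCCc1nc(N)c2nc(O)n(Cc3ccccc3)c2n1` and compound 2 `CCCCCOc1nc(N)c2nc(O)n(Cc3ccccc3)c2n1` share one core and differ in a single side chain. In a functional assay on the whole organism for activation, with Mus musculus as the target (a higher number here means that more compound is needed for the effect, a lower number that less compound is needed), compound 1 gives 0.3 mg/kg, and compound 2 gives 0.3 mg/kg; the step of no change at the digits printed from compound 1 to compound 2 (within the scatter) shows that this exchange left the dose unchanged within the scatter. Among the compounds with values here, compound 2 therefore stands level with compound 1 on the numbers so far. Compound 3 `CCCCCSc1nc(N)c2nc(O)n(Cc3ccccc3)c2n1` has not yet been measured. It differs from compound 2 as follows: pentylsulfanyl in place of pentyloxy on an aromatic carbon. Within the data shown here, the only measured step bears on this change indirectly: it altered the same chain at the same place and produced nothing beyond the scatter, but it did not test sulfur in place of oxygen, so the expectation rests on one comparison. Compound 3 is therefore estimated at 0.3 mg/kg, within 0.1 mg/kg to 1 mg/kg. The step of no change at the digits printed from compound 2 to compound 3 (within the scatter) is expected to remain within the scatter.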

Compound 3, minimum effective dose: 1 mg/kg
Beside the measured number, compound 3's estimate is 3.3-fold (0.52 log units) below it; measured number inside the range.
By their numbers in this assay, from the lowest: compounds 1 and 2 (each within the scatter of the next); then compound 3.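

In this assay, within the data shown here, the atom linking the pentyl chain to the shared core matters: pentylsulfanyl in place of pentyloxy gives a 3.3-fold higher number from compound 2 to compound 3 (0.52 log units; beyond the scatter) and is the first exchange here to go beyond the scatter. Pentylsulfanyl in place of butyl likewise gives a 3.3-fold higher number from compound 1 to compound 3 (0.52 log units; beyond the scatter) at this same spot, so this aromatic carbon between two ring nitrogen atoms is not indifferent to its side chain, even though pentyloxy in place of butyl left the dose level. No evidence is at hand to explain why the sulfur-linked chain needs a higher dose than the oxygen-linked one.

The compounds shown leave open how an amine linking the pentyl chain at this carbon would compare. Also open, going by these compounds, is whether a longer chain on the sulfur would give a step of similar size.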